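A few compounds are considered here, and "the series" means these few. Any claim that something is new, unique, unknown or untested is made for them only; others in the source may bear on it.

Measured so far:
- compound 1, `CC(=O)Oc1ccc(CONC(=O)c2ccc(CS(=O)(=O)Nc3ccc4cc(C)c(=O)n(C)c4c3)cc2)cc1`, in a functional assay on THP-1 cells (Homo sapiens) for antiproliferative activity, tested at 1 uM (a higher number here means a stronger effect of the compound at the concentration tested, a lower number a weaker effect), gives 4%
- compound 2, `COC(=O)c1ccc(CS(=O)(=O)Nc2ccc3c(c2)cc(C)c(=O)n3C)cc1`, in this assay gives 0%

Compound 2 stands beside compound 1 on the numbers shown: the gap between the two values lies within the usual scatter, so neither can be called weaker or stronger, and both sit near the floor of the read-out. Compound 3, `Cc1cc2cc(NS(=O)(=O)Cc3ccc(C(=O)NO)cc3)ccc2n(C)c1=O`, remains to be measured in this assay. It differs from compound 2 at one place, (hydroxyamino in place of methoxy on a carbonyl carbon), so that the methoxycarbonyl of compound 2 becomes a hydroxycarbamoyl in compound 3.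

Among the compounds with values here, no measured pair differs at only this position, so no step is known that would fix the size or direction of the change. Within the data shown here, the only guidance is that compound 2 gives 0% and cannot fall much lower. The step from compound 2 to compound 3 is therefore estimated as upward, a number 30 percentage points higher from compound 2 to compound 3 (beyond the scatter), with a broad range to either side. Compound 3 is expected to give about 30%, between 0% and 75%.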

Compound 3, a percentage reported as inhibition, at one concentration (the size of the read-out at that concentration, not a potency): 0%
For compound 3 the middle estimate is 30 percentage points above the measured one; measured number inside the range.
By their numbers in this assay, from the lowest: compounds 2, 3 and 1 (each within the scatter of the next).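

In this assay, within the data shown here, the exchange of methoxy for hydroxyamino on a carbonyl carbon, which turns methoxycarbonyl into hydroxycarbamoyl, reads as no change at the digits printed from compound 2 to compound 3 (within the scatter) and is the first measured step at this position. The exchange brings in two hydrogen-bond donors where the methoxy held none, yet compound 3 gives 0% at the single concentration tested. Nothing at hand bears on why this is so.

With both members of the pair at the floor, the step fixes no direction or size for this position, and a difference that shows only at other concentrations cannot be excluded. Also open, on these data alone, is whether a carboxylic acid or a primary amide on the same carbonyl carbon, or a longer chain carrying the hydroxycarbamoyl, would give a read-out clear of the floor in this assay on the shared core.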